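This account rests on a few compounds, and the source may have more. Where it says the series, first, only, none or still open, it means among the compounds named here.

Measured so far:
compound 1, `O=[N+]([O-])c1ccc(CN2CCC(n3cc(CC(OCc4cc(-c5ccc(Br)cc5)no4)c4ccc(Br)cc4)nn3)CC2)cc1`, 2000 nM
compound 2, `O=[N+]([O-])c1ccc(CN2CCC(n3cc(CC(OCc4cc(-c5ccc(F)cc5)no4)c4ccc(Br)cc4)nn3)CC2)cc1`, 2000 nM
compound 3, `O=[N+]([O-])c1ccc(CN2CCC(n3cc(CC(OCc4cc(-c5ccccc5Br)no4)c4ccc(Br)cc4)nn3)CC2)cc1`, reported only as a limit

In a functional assay on Huh-7 cells (Homo sapiens) for cytotoxicity, with a stated time of 48 h (on this read-out higher numbers stand for weaker inhibition and lower numbers for stronger inhibition), compound 1 gives 2000 nM and compound 2 gives 2000 nM. For compound 3 this assay gives only a limit, > 25000 nM, and no number, as noted in the limit of > 25000 nM in this assay, at which 1 of the 3 values shown sits. Compound 2 differs from compound 1 by fluoro in place of bromo on an aromatic carbon, and this gave no change at the digits printed from compound 1 to compound 2 (within the scatter). Compound 3 differs from compound 1 in its core by 2-bromophenyl in place of 4-bromophenyl on an aromatic carbon, and this gave an at least 12-fold higher number from compound 1 to compound 3 (1.09 log units; beyond the scatter).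

Compound 4, `O=[N+]([O-])c1ccc(CN2CCC(n3cc(CC(OCc4cc(-c5ccccc5F)no4)c4ccc(Br)cc4)nn3)CC2)cc1`, is not yet measured. It differs from compound 3 by fluoro in place of bromo on an aromatic carbon. Within the data shown here, this is the same kind of change as the one from compound 1 to compound 2, not the same: there the place was para to a large group, here it is ortho to a large group. From the earlier step of no change at the digits printed from compound 1 to compound 2 (within the scatter), the step from compound 3 to compound 4 is expected to be a step that the limit leaves unreadable from compound 3 to compound 4. Compound 4 is therefore estimated at 30000 nM in this assay, most likely again reported as a limit.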

Compound 4, half-maximal inhibitory concentration: 2000 nM
The estimate for compound 4 lay 15-fold (1.18 log units) above the measured number, outside the stated range (below it).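

In this assay, the swap of bromo for fluoro did not carry over unchanged from one core to the other: the same change on two cores in this assay, no change at the digits printed (within the scatter) from compound 1 to compound 2 and an at least 12-fold lower number (1.09 log units; beyond the scatter) from compound 3 to compound 4, at least 12-fold (1.09 log units) apart, beyond the scatter of two such steps

Moving the halogen and changing it gives no change at the digits printed from compound 2 to compound 4 (within the scatter) and no change at the digits printed from compound 1 to compound 4 (within the scatter), so among these four compounds only compound 3 stands apart, while the swap on its core gives an at least 12-fold lower number from compound 3 to compound 4 (1.09 log units; beyond the scatter). Compound 3 carries a limit rather than a number, so the full size of that last step stays unknown, and the pair of cores shows only that a swap without effect on one core can have a large effect on another, not why this happens or whether it holds for further cores: the limit of > 25000 nM in this assay, at which 1 of the 4 values shown sits.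

Chloro, methoxy or an amine in place of the halogen on that phenyl ring would be new cases. Going by these compounds, whether any of them would read like compound 3 or like compound 4 in this assay stays open.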